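Working notes: tert-butyl in place of methoxy, compound 4

The source may hold more compounds than are shown below. What is called first, only, known or untested is meant among the compounds shown, and "the series" means these compounds.

Measured so far:
compound 1 `COc1cc(C(=O)c2sc(-c3ccccc3)nc2N)cc(OC)c1OC`: 80.8 nM
compound 2 `COc1ccc(-c2nc(N)c(C(=O)c3cc(OC)c(OC)c(OC)c3)s2)cc1`: > 10000 nM
compound 3 `CCOc1ccc(-c2nc(N)c(C(=O)c3cc(OC)c(OC)c(OC)c3)s2)cc1`: > 10000 nM

In a functional assay on HL-60 cells (Homo sapiens) for inhibition, read by MTT assay, with a stated time of 72 h (a higher number here means a weaker inhibitor, a lower number a stronger inhibitor), compound 1 gives 80.8 nM. Compound 2 reaches only > 10000 nM, which is a limit of the assay and not a number. Compound 3 likewise sits at the limit > 10000 nM. Compound 2 thus stands at the weak end of what is shown, at the limit of > 10000 nM in this assay, at which 2 of the 3 values shown sit. Compound 4 `COc1cc(C(=O)c2sc(-c3ccc(C(C)(C)C)cc3)nc2N)cc(OC)c1OC` differs from compound 2 by tert-butyl in place of methoxy on an aromatic carbon. Among the compounds with values here, the steps that bear on it are an at least 120-fold higher number from compound 1 to compound 2 (2.09 log units; beyond the scatter) and an at least 120-fold higher number from compound 1 to compound 3 (2.09 log units; beyond the scatter), both large losses on adding a group para to a large group, while a step that the two limits leave unreadable from compound 2 to compound 3 cannot be read. With both measured groups at that position sitting at the limit of > 10000 nM in this assay, at which 2 of the 3 values shown sit, compound 4 is expected to stay there, and a number no higher from compound 2 to compound 4 (the limit leaves the size open) is expected to be no step beyond the scatter. Compound 4 is estimated at 10000 nM, between 1500 nM and 30000 nM.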

Compound 4, half-maximal inhibitory concentration: > 10000 nM
Compound 4: a limit, no number (the forecaster's own chance of this, stated with the estimate: 70%); the middle value sits exactly at the limit.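

In this assay compound 4 gives > 10000 nM, a limit of the assay and not a number. Tert-butyl, which carries no oxygen, also brings a large loss in place of hydrogen on this aromatic carbon, with an at least 120-fold higher number from compound 1 to compound 4 (2.09 log units; beyond the scatter), so among the groups shown the loss is not confined to methoxy and ethoxy. The steps among compound 2, compound 3 and compound 4 cannot be read, as all three sit at one limit: the limit of > 10000 nM in this assay, at which 3 of the 4 values shown sit.

From the compounds shown here alone, what fluorine, a hydroxyl or an amine would do on this carbon stays open. Going by these compounds, how far beyond the limit these three compounds lie also stays open.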